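The source may report more compounds than this note shows. Statements on the series, on what has been measured and on what is new or still open speak of the compounds shown alone.

In a functional assay on DLD-1 cells (Homo sapiens) for antiproliferative activity, read by CellTiter-Glo, with a stated time of 72 h (on this read-out higher numbers stand for weaker inhibition and lower numbers for stronger inhibition), compound 2, `CC1CCN(C2CCN(S(=O)(=O)c3ccc(Cl)c(Cl)c3)CC2)CC1`, gives 2.9 nM, and compound 1, `CC1CCN(C2CCN(S(=O)(=O)c3cccc(-c4ccccc4F)c3)CC2)CC1`, gives 10 nM. Compound 3, `CC1CCN(C2CCN(S(=O)(=O)c3cncc(Br)c3)CC2)CC1`, reports only a limit in this assay, > 5000 nM. For the measured compounds named here, the step of an at least 1700-fold higher number from compound 2 to compound 3 (3.23 log units; beyond the scatter) is the one measured change on the sulfonyl sulfur, and its end point sits at the limit of > 5000 nM in this assay, at which 1 of the 3 values shown sits, so compound 3 stands as the one compound without a number, at the edge of what this assay can read. Compound 4, `COc1cccc(S(=O)(=O)N2CCC(N3CCC(C)CC3)CC2)c1`, differs from compound 3 by 3-methoxyphenyl in place of 5-bromopyridin-3-yl on a sulfonyl sulfur. Going by the values given here, only the step from compound 2 to compound 3 bears on this change, and it ran the other way: a six-membered aromatic ring of carbon only was exchanged for one with a hetero atom, and the number rose beyond the limit. Returning to a carbon-only ring is therefore expected to bring the number back down by a large amount, though the methoxy group has no measured counterpart among compounds 1 and 2. Compound 4 is expected to give 100 nM in this assay, between 20 nM and 1000 nM. This estimate means a step of an at least 50-fold lower number from compound 3 to compound 4 (1.69 log units; beyond the scatter).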

Compound 4, half-maximal inhibitory concentration: > 5000 nM
Compound 4 ended at the assay's limit (the forecaster's own chance of this, stated with the estimate: 15%); middle value at least 50-fold (1.69 log units) away from the limit.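

A six-membered aromatic ring of carbon only on the sulfonyl sulfur is therefore not enough on its own: in this assay, 3-methoxyphenyl in place of 3,4-dichlorophenyl gives an at least 1700-fold higher number from compound 2 to compound 4 (3.23 log units; beyond the scatter), and methoxy in place of 2-fluorophenyl gives an at least 500-fold higher number from compound 1 to compound 4 (2.69 log units; beyond the scatter). Among these four compounds, what the ring carries counts, not only whether the ring holds a hetero atom. Compound 4 reports only a limit, as compound 3 does, so the step between these two compounds cannot be read: the limit of > 5000 nM in this assay, at which 2 of the 4 values shown sit.

From the compounds shown here alone, how far compound 3 and compound 4 lie past that limit stays unknown. Also open, going by these compounds, is whether a hydroxyl or an amine in place of the methoxy group would bring the number back down, or whether only groups like the chlorines of compound 2 do so.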